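The source may report more compounds than this note shows. Statements on the series, on what has been measured and on what is new or still open speak of the compounds shown alone.

Of the compounds shown here, three sharing one core have been measured in a functional assay on KB cells (Homo sapiens) for cytotoxicity; on this read-out higher numbers stand for an effect only at larger amounts of compound and lower numbers for an effect already at smaller amounts. Compound 1 `Oc1ccc2nc(-c3ccccc3)cc(O)c2c1` carries a hydroxy on its carbocyclic ring and gives 0.41 ug/mL. Compound 3 `CCOc1cc(-c2ccccc2)nc2ccccc12`, which has an ethoxy in place of the hydroxy on the other ring and no substituent on the carbocyclic ring, gives 6.7 ug/mL. Compound 2 `Oc1cc(-c2ccccc2)nc2cc(F)ccc12` carries a fluoro on the carbocyclic ring. For compound 2 the outcome in this assay is only a limit, < 0.1 ug/mL, so its true value is not known as a number. This limit, (the limit of < 0.1 ug/mL in this assay, at which 1 of the 3 values shown sits), marks the end of the measurable range, and one of the three values shown sits there, which places compound 2 at the most potent end of what has been measured.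

Compound 4 `Oc1ccc2c(O)cc(-c3ccccc3)nc2c1` is the not yet measured partner of compound 2. The change from compound 2 to compound 4 is hydroxy in place of fluoro on an aromatic carbon.

Going by the values given here, since no pair of measured compounds differs in just one place, no measured step tells how much such a swap shifts the read-out. Compound 1, with a hydroxy on the same ring in another position, gives 0.41 ug/mL, which suggests a hydroxy on this ring still allows a value well below that of compound 3. The expected step from compound 2 to compound 4 is an at least 3.0-fold higher number from compound 2 to compound 4 (0.47 log units; beyond the scatter), a modest loss of potency that may well lie within the scatter. Compound 4 is estimated at 0.3 ug/mL, with a likely range from 0.08 ug/mL to 1.2 ug/mL.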

Compound 4, half-maximal effective concentration: 0.55 ug/mL
Compound 4: middle estimate off by 1.8-fold (0.26 log units), on the low side, within the range that was stated.
By their numbers in this assay, from the lowest: compounds 1 and 4 (each within the scatter of the next); then compound 3. At a limit, below all of these: compound 2.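

Going by these compounds alone, the swap of fluoro for hydroxy, at the aromatic carbon that lies meta to a fused ring and para to a fused ring, is the first change that can be read on its own, and in this assay it gives an at least 5.5-fold higher number from compound 2 to compound 4 (0.74 log units; beyond the scatter) on the shared core. This shows that the two groups are not interchangeable at this position: with the hydroxy, the effect on the cells needs a clearly larger amount of compound than with the fluoro. The step gives only a minimum for the shift and not its true size, because compound 2 stands at a limit of the assay: the limit of < 0.1 ug/mL in this assay, at which 1 of the 4 values shown sits.

As far as these compounds go, how large the gap really is remains open, and a value for the fluoro compound on a scale that reaches further down would be needed to settle it. Also open, from the compounds shown here alone, is how other groups at this position, such as a chloro, a methoxy or an amine, would compare, and whether the same swap would shift the read-out equally at another carbon of this ring.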